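Methoxy placement on the cyclopropyl quinoline urea core

The source may hold more compounds than are shown below. What is called first, only, known or untested is meant among the compounds shown, and "the series" means these compounds.

Within the data shown here, compound 1 `O=C(Nc1cnc(-n2nccn2)c(Cl)c1)Nc1cnc2ccccc2c1C1CC1` gives 1580 nM in a functional assay on OCI-Ly3 cells (Homo sapiens) for antiproliferative activity (a higher number here means that more compound is needed for the effect, a lower number that less compound is needed), and is the only compound in this set with a measured number. Compound 2 `COc1ccc2c(C3CC3)c(NC(=O)Nc3cnc(-n4nccn4)c(Cl)c3)cnc2c1` gives > 20000 nM in this assay, which is a limit of the assay and not a number. Compound 2 carries a methoxy in place of hydrogen on an aromatic carbon of the shared core, and the step of an at least 12-fold higher number from compound 1 to compound 2 (1.10 log units; beyond the scatter) is large, with compound 2 sitting at the limit of > 20000 nM in this assay, at which 1 of the 2 values shown sits.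

Compound 3 `COc1ccc2ncc(NC(=O)Nc3cnc(-n4nccn4)c(Cl)c3)c(C3CC3)c2c1` has not yet been measured. It differs from compound 1 by methoxy in place of hydrogen on an aromatic carbon. The methoxy of compound 3 sits on a different aromatic carbon of the same ring from that of compound 2. Among the measured compounds shown here, the only measured step that bears on this change is an at least 12-fold higher number from compound 1 to compound 2 (1.10 log units; beyond the scatter), which went toward more compound being needed. A step in the same direction in this assay is therefore expected, although a different carbon need not carry the same weight, so the expected step is smaller and wide in its uncertainty. Compound 3 is estimated at 6000 nM, within 1500 nM to 30000 nM. This corresponds to an expected step of a 3.8-fold higher number from compound 1 to compound 3 (0.58 log units; beyond the scatter).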

Compound 3, half-maximal effective concentration: 2390 nM
For compound 3 the middle estimate is 2.5-fold (0.40 log units) above the measured one, and the stated range covers the measured number.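

In this assay, methoxy in place of hydrogen on this aromatic carbon, meta to a fused ring and para to a fused ring, gives a 1.5-fold higher number from compound 1 to compound 3 (0.18 log units; within the scatter), so compound 1 and compound 3 cannot be told apart in this read-out. The effect of adding a methoxy to this ring therefore depends on which carbon carries it, since the other placement gave an at least 12-fold higher number from compound 1 to compound 2 (1.10 log units; beyond the scatter). Compound 2 remains the only compound in the set without a measured number, so its gap to compound 3 has no defined size: the limit of > 20000 nM in this assay, at which 1 of the 3 values shown sits.

What a methoxy does on the remaining carbons of this ring stays open, and the compounds shown offer no explanation for the contrast between the two placements. Also open, on these data alone, is whether an amine, a fluorine or a longer alkoxy chain on the carbon that carries the methoxy of compound 3 would stay within the scatter of compound 1 or move the number in this assay in either direction.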